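The compounds below may be only part of what the source reports. "The series", "measured", "known", "first", "only" and "open" are said of these compounds alone.

Compound 1, `CN(c1cccc(Br)c1)c1ncnc2ccc(Cl)cc12`: > 30000 nM
Compound 2, `Clc1ccc2ncnc(Sc3cccc(Br)c3)c2c1`: > 30000 nM
Compound 3, `CN(c1cccc(Br)c1)c1ncnc2ccc(Br)cc12`: > 30000 nM

All three measured compounds were tested in a functional assay on HEK293 cells for antagonist activity at metabotropic glutamate receptor 5 (Rattus norvegicus), read by calcium flux; a higher number here means a weaker inhibitor, a lower number a stronger inhibitor. In this assay compound 1 gives > 30000 nM, which is a limit of the assay and not a number. Compound 3, in this assay, likewise gives > 30000 nM, again a limit. Compound 2 gives > 30000 nM in this assay, also a limit. The difference between the cores of compound 1 and compound 2 is not broken down here.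

Compound 1 and compound 3 differ in one place: bromo in place of chloro on an aromatic carbon The step between them, a step that the two limits leave unreadable from compound 1 to compound 3, cannot be sized because of the limit of > 30000 nM in this assay, at which 3 of the 3 values shown sit.

Compound 4, `Brc1cccc(Sc2ncnc3ccc(Br)cc23)c1`, is not yet measured. It differs from compound 2 in the same way: bromo in place of chloro on an aromatic carbon The two places are described in identical words, so this is the same change as that from compound 1 to compound 3.

Among the compounds with values here, the only earlier example of this change gave a step whose size is unreadable, and every value shown sits at the limit. The step that the limit leaves unreadable from compound 2 to compound 4 is therefore expected to be negligible. Compound 4 is expected to give 40000 nM, with a plausible range from 15000 nM to 120000 nM, and most likely only another limit will be reported.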

Compound 4, half-maximal inhibitory concentration: > 30000 nM
Compound 4 ended at the assay's limit (the forecaster's own chance of this, stated with the estimate: 85%); the middle value lies beyond the limit too.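

Compound 2 and compound 4 both rest at a limit of this assay and not at a number, so no size can be read for the step between them, because all the values sit at one limit: the limit of > 30000 nM in this assay, at which 4 of the 4 values shown sit.

The compounds shown leave open whether bromo in place of chloro changes inhibition at all, and whether any compound with these cores gives a measurable value in this assay.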